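Swapping the methoxyphenyl for a difluorophenyl on the chalcone

The compounds below may be only part of what the source reports. "The series", "measured", "known", "first", "only" and "open" are said of these compounds alone.

Compound 2 `COc1ccc(C(=O)/C=C/c2cc(-c3cc(OC)c(OC)c(OC)c3)n[nH]2)cc1` and compound 1 `COc1ccc(C(=O)/C=C/c2cc(-c3cc(OC)c(OC)c(OC)c3)n[nH]2)cc1OC` share a core and differ only by hydrogen in place of methoxy on an aromatic carbon. In a functional assay on SR cells (Homo sapiens) for cytotoxicity, read by sulforhodamine B assay, with a stated time of 48 h, tested at 0.1 uM (a higher number here means a weaker effect of the compound at the concentration tested, a lower number a stronger effect), compound 1 gives 81%, and compound 2 gives 83%, the two values lying within the scatter of each other, as the step of a number 2 percentage points higher from compound 1 to compound 2 (within the scatter) shows. Compound 3 `COc1cc(-c2cc(/C=C/C(=O)c3ccc(F)c(F)c3)[nH]n2)cc(OC)c1OC` carries a larger change: 3,4-difluorophenyl in place of 4-methoxyphenyl on a carbonyl carbon. Among the compounds with values here, the only measured step that bears on it, the removal of a methoxy, stayed within the scatter, so no step beyond the scatter is expected here, with a number 1 percentage points lower from compound 2 to compound 3 (within the scatter). Compound 3 is therefore expected to give about 82% in this assay, within the range 65% to 96%.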

Compound 3, a percentage reported as activity, at one concentration (the size of the read-out at that concentration, not a potency): 106%
For compound 3 the middle estimate is 24 percentage points below the measured one, outside the stated range (above it).
By their numbers in this assay, from the lowest: compounds 1 and 2 (each within the scatter of the next); then compound 3.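

At this position on a carbonyl carbon, the aromatic group is not interchangeable: losing one methoxy left the read-out in this assay within the scatter, whereas 3,4-difluorophenyl gives a number 23 percentage points higher from compound 2 to compound 3 (beyond the scatter) and a number 25 percentage points higher from compound 1 to compound 3 (beyond the scatter) in comparison with 3,4-dimethoxyphenyl. Since a higher number means a weaker effect, both steps show a loss of effect at the concentration tested. Nothing available accounts for this loss.

Going by these compounds, it remains open whether one fluorine alone would behave the same way. On these data alone, the effect of an amine or a carboxylic acid on this phenyl ring also remains unknown.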